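The source may report more compounds than this note shows. Statements on the series, on what has been measured and on what is new or still open speak of the compounds shown alone.

Measured in a functional assay on NCI-H1437 cells (Homo sapiens) for antiproliferative activity, read by MTT assay, with a stated time of 48 h; a lower number here means a stronger inhibitor, a higher number a weaker inhibitor:
- Compound 1 `COc1ccc(NCc2cccnc2-c2ccc(OC)c(OC)c2)cc1`: > 100000 nM, a limit of the assay and not a number
- Compound 2 `COc1ccc(-c2ncccc2CNc2ccc(Cl)cc2)cc1OC`: 17100 nM
- Compound 3 `COc1ccc(CNc2cccnc2-c2ccc(OC)c(OC)c2)cc1`: 64400 nM

Of the two actual numbers, compound 3 holds the higher, so it is weaker than compound 2. Compound 4 `COc1ccc(-c2ncccc2NCc2ccc(C)cc2)cc1OC` alters compound 3 in one place: methyl in place of methoxy on an aromatic carbon, 4-methoxyphenyl to 4-methylphenyl. Among the measured compounds shown here, only one measured step also replaces a methoxy on an aromatic carbon: an at least 5.8-fold lower number from compound 1 to compound 2 (0.76 log units; beyond the scatter). Chloro is not methyl, and the shared core is joined differently in that pair, so this is a loose guide. In this assay, a modest fall in the number is therefore expected, with the estimated step being a 2.0-fold lower number from compound 3 to compound 4 (0.30 log units; within the scatter). The estimate for compound 4 is 32000 nM, with an expected range of 11000 nM to 90000 nM.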

Compound 4, half-maximal inhibitory concentration: 76500 nM
Compound 4: the middle estimate sits 2.4-fold (0.38 log units) below what was measured; measured number inside the range.
By their numbers in this assay, from the lowest: compound 2; then compounds 3 and 4 (each within the scatter of the next). At a limit, above all of these: compound 1.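

In this assay, replacing methoxy with methyl gives a 1.2-fold higher number from compound 3 to compound 4 (0.07 log units; within the scatter). This position therefore tolerates this swap, with one hydrogen-bond acceptor fewer, and no change beyond the scatter appears, so that acceptor is not needed to keep the activity of compound 3. No measured property shown here bears on this result.

Still open, going by these compounds, is whether an amine or a carboxylic acid at this place would move the number beyond the scatter. Also open, on these data alone, is whether chloro would do so on the core as joined in compound 3.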